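Swapping the oxygen-bearing ring on the shared core

The compounds below may be only part of what the source reports. "The series", "measured", "known", "first", "only" and "open" are said of these compounds alone.

Measured in an assay on brain for inhibition of Monoglyceride lipase (Mus musculus), with a stated time of 30 min; a higher number here means a weaker inhibitor, a lower number a stronger inhibitor:
compound 1 `O=C(OC(C(F)(F)F)C(F)(F)F)N1CCN(Cc2ccc(C(F)(F)F)cc2N2CCCCC2)CC1` gives 130 nM
compound 2 `O=C(OC(C(F)(F)F)C(F)(F)F)N1CCN(Cc2ccc(C(F)(F)F)cc2N2C[C@H]3CC[C@@H](C2)O3)CC1` gives 14 nM
compound 3 `O=C(OC(C(F)(F)F)C(F)(F)F)N1CCN(Cc2ccc(C(F)(F)F)cc2N2CC[C@H](O)C2)CC1` gives 15 nM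

Compound 2 has the lowest number of the three, but compound 3 sits within the scatter of it, so the two cannot be ranked. Compound 4 `O=C(OC(C(F)(F)F)C(F)(F)F)N1CCN(Cc2ccc(C(F)(F)F)cc2N2CCC3(CCOCC3)C2)CC1` differs from compound 2 by a group of 10 heavy atoms (8 carbon, 1 nitrogen, 1 oxygen; one five-membered non-aromatic ring with 1 hetero atom, one six-membered non-aromatic ring with 1 hetero atom) in place of a group of 8 heavy atoms (6 carbon, 1 nitrogen, 1 oxygen; one five-membered non-aromatic ring with 1 hetero atom, one six-membered non-aromatic ring with 2 hetero atoms), on an aromatic carbon. Among the compounds with values here, the steps that bear on this are a 9.3-fold lower number from compound 1 to compound 2 (0.97 log units; beyond the scatter) and an 8.7-fold lower number from compound 1 to compound 3 (0.94 log units; beyond the scatter), both modest drops when an oxygen-bearing ring replaced piperidin-1-yl, while a 1.1-fold higher number from compound 2 to compound 3 (0.03 log units; within the scatter) shows that the shape and size of that ring mattered little. Compound 4 keeps an oxygen-bearing ring, so the expected step is a 1.4-fold higher number from compound 2 to compound 4 (0.15 log units; within the scatter), within the scatter. Compound 4 is estimated at 20 nM, between 7 nM and 60 nM.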

Compound 4, half-maximal inhibitory concentration: 24 nM
Beside the measured number, compound 4's estimate is 1.2-fold (0.08 log units) below it; measured number inside the range.
By their numbers in this assay, from the lowest: compounds 2, 3 and 4 (each within the scatter of the next); then compound 1.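

With 10 heavy atoms in place of 8, the group on this aromatic carbon grows with little effect: a 1.7-fold higher number from compound 2 to compound 4 (0.23 log units; within the scatter), and a 1.6-fold higher number from compound 3 to compound 4 (0.20 log units; within the scatter). Even this larger oxygen-bearing group keeps compound 4 well ahead of the piperidin-1-yl compound, with a 5.4-fold lower number from compound 1 to compound 4 (0.73 log units; beyond the scatter). No measurement shown explains this tolerance. Going by these compounds, whether the oxygen itself sets these groups apart from piperidin-1-yl stays open. Also open, on these data alone, is how a plain pyrrolidin-1-yl group, without oxygen, or a 3-aminopyrrolidin-1-yl group would compare.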